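Swapping a nitrile for an aryl sulfide on two cores

A few compounds are considered here, and "the series" means these few. Any claim that something is new, unique, unknown or untested is made for them only; others in the source may bear on it.

Compound 1 `Cc1cc(C#N)cn2c(CSCCc3ccccc3)cnc12` gives 20 ug/mL in an ADME assay on HEL cells (Homo sapiens) for cytotoxicity, with a stated time of 3 days; on this read-out lower numbers stand for higher toxicity in this test and higher numbers for lower toxicity in this test.
Compound 2 `Cc1cc(Sc2ccc(Cl)cc2)cn2c(CSCCc3ccccc3)cnc12` gives 20 ug/mL in this assay.
Compound 3 `Cc1cc(C#N)c2ncc(CSCCc3ccccc3)n2c1` gives >= 20 ug/mL in this assay, which is a limit of the test and not a number.

Compounds 1 and 2 share a core and differ by (4-chlorophenyl)sulfanyl in place of cyano on an aromatic carbon; this gave no change at the digits printed from compound 1 to compound 2 (within the scatter). Compound 3 has the same atoms as compound 1 joined differently; the difference between the two cores is not broken down here. Compound 4 `Cc1cc(Sc2ccc(Cl)cc2)c2ncc(CSCCc3ccccc3)n2c1` is not yet measured. It differs from compound 3 by (4-chlorophenyl)sulfanyl in place of cyano on an aromatic carbon, the same kind of change as before, though here the site is ortho to a fused ring where before it was para to a fused ring. The step from compound 3 to compound 4 is expected to be a number no higher from compound 3 to compound 4 (the limit leaves the size open), resting on no change at the digits printed from compound 1 to compound 2 (within the scatter). Since compound 3 sits at the limit of >= 20 ug/mL in this assay, at which 1 of the 3 values shown sits, compound 4 may likewise come back as a limit. Compound 4 is estimated at 20 ug/mL, between 10 ug/mL and 40 ug/mL.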

Compound 4, minimum cytotoxic concentration: 4 ug/mL
The estimate for compound 4 lay 5.0-fold (0.70 log units) above the measured number, outside the stated range (below it).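

On the second core, putting (4-chlorophenyl)sulfanyl in place of cyano gave an at least 5.0-fold lower number from compound 3 to compound 4 (0.69 log units; beyond the scatter) in this assay, so the result of this change did not carry over from the first core: the same change on two cores in this assay, no change at the digits printed (within the scatter) from compound 1 to compound 2 and an at least 5.0-fold lower number (0.69 log units; beyond the scatter) from compound 3 to compound 4, at least 5.0-fold (0.69 log units) apart, beyond the scatter of two such steps. Compound 3 gives >= 20 ug/mL, which is a limit of the test and not a number. On this read-out, the lower number for compound 4 stands for higher toxicity, so a flat result on one core was no safe guide to the other; with one pair per core, this does not show why the two cores part ways.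

Going by these compounds, whether an amine or a carboxylic acid in place of cyano would also behave differently on the two cores remains open. So does whether a chain longer or shorter than the phenethyl sulfide arm would alter the gap.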